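From compound 1 to a furan-2-yl analogue

The compounds below may be only part of what the source reports. "The series", "measured", "known", "first", "only" and "open" are said of these compounds alone.

Compound 1 `c1ccc(-c2cc(-c3ccsc3)cc(-c3ccccn3)n2)nc1` gives 0.62 ug/mL in a functional assay on A549 cells (Homo sapiens) for antiproliferative activity (on this read-out lower numbers stand for stronger inhibition of growth and higher numbers for weaker inhibition of growth), the lowest number among the compounds measured here. Compound 3 `c1ccc(-c2cc(-c3cccs3)cc(-c3cccnc3)n2)nc1` gives 78.9 ug/mL in this assay, a much higher number. For compound 2 `c1ccc(-c2cc(-c3ccsc3)cc(-c3cccnc3)n2)nc1` only > 100 ug/mL is known in this assay, and that is a limit of the assay, not a number. The move an at least 160-fold higher number from compound 1 to compound 2 (2.20 log units; beyond the scatter) was large, whereas an at least 1.2-fold lower number from compound 2 to compound 3 (0.10 log units; that floor lies within the scatter) stayed small, although the limit of > 100 ug/mL in this assay, at which 1 of the 3 values shown sits, caps what that second step can reveal. Compound 4 `c1ccc(-c2cc(-c3ccco3)cc(-c3ccccn3)n2)nc1` differs from compound 1 by furan-2-yl in place of thiophen-3-yl on an aromatic carbon, an exchange of one five-membered ring for another, closer in kind to the thiophen-2-yl for thiophen-3-yl exchange than to the pyridine exchange. In this assay compound 4 is therefore expected to show only a small step, a 1.6-fold higher number from compound 1 to compound 4 (0.21 log units; within the scatter), within the scatter, giving an estimated 1 ug/mL with a range of 0.3 ug/mL to 4 ug/mL.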

Compound 4, concentration for 50% growth inhibition: 0.22 ug/mL
For compound 4 the middle estimate is 4.5-fold (0.66 log units) above the measured one; measured number outside the range, below it.
By their numbers in this assay, from the lowest: compound 4; then compound 1; then compound 3. At a limit, above all of these: compound 2.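

Exchanging thiophen-3-yl for furan-2-yl gives a 2.8-fold lower number from compound 1 to compound 4 (0.45 log units; beyond the scatter) in this assay, so this position, opposite the ring nitrogen, tolerates a change of five-membered ring, and growth inhibition grows modestly stronger. Compound 2 has only a limit, so the earlier five-membered ring exchange could not be sized, whereas this one is read between two real numbers. Nothing shown here explains the gain.

This exchange alters both the hetero atom and the point of attachment, and the compounds shown do not separate the two. As far as these compounds go, whether an amine or a longer chain would work at this position also stays open.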